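This account rests on a few compounds, and the source may have more. Where it says the series, first, only, none or still open, it means among the compounds named here.

Compound 1 `O=C(COCc1ccccc1)N1CCN(c2ccccc2Cl)CC1`: 1100 nM
Compound 2 `O=C(COCc1ccncn1)N1CCN(c2ccc(Cl)cc2Cl)CC1`: 2800 nM
Compound 3 `CN(CC(=O)N1CCN(c2ccc(Cl)cc2Cl)CC1)Cc1ccncc1`: > 25000 nM

Of the compounds shown here, three on the shared core have been measured in a functional assay on HEK293 cells for positive allosteric modulation of metabotropic glutamate receptor 5 (Homo sapiens), read by FLIPR and calcium flux; a higher number here means that more compound is needed for the effect, a lower number that less compound is needed. Compound 2 gives 2800 nM, which is the highest of the two numbers reported; the nearest neighbour is compound 1, whose value of 1100 nM sits lower by a margin beyond the usual scatter. Compound 3 is reported only as a limit of the assay, > 25000 nM, and not as a number; this is the limit described as the limit of > 25000 nM in this assay, at which 1 of the 3 values shown sits.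

The piece now follows the step from compound 2 to compound 4 `O=C(CSc1ccccc1)N1CCN(c2ccc(Cl)cc2Cl)CC1`, which has not yet been measured in this assay. The change is phenylsulfanyl in place of (pyrimidin-4-yl)methoxy on a saturated chain carbon bound to a carbonyl carbon. The rest of compound 2 is kept, so the step concerns only the group at the far end of the amide chain.

For the measured compounds named here, no measured pair differs in exactly this way, so the expectation rests on what compounds 1 and 2 show. Since compound 1 carries a carbon-only aromatic ring at that end and gives 1100 nM, compound 4 is expected to land near that region or near compound 2 itself. The estimated step of a 1.9-fold lower number from compound 2 to compound 4 (0.27 log units; within the scatter) is thus a modest one toward a lower number, within or just beyond the scatter. For compound 4 the estimate is 1500 nM, with a range from 400 nM to 6000 nM.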

Compound 4, half-maximal effective concentration: > 25000 nM
Compound 4 was reported as a limit; the forecaster's own chance of this, stated with the estimate: 15%; middle value at least 16-fold (1.22 log units) away from the limit.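

In this assay, phenylsulfanyl in place of (pyrimidin-4-yl)methoxy on a saturated chain carbon bound to a carbonyl carbon is far from a neutral exchange, giving an at least 8.9-fold higher number from compound 2 to compound 4 (0.95 log units; beyond the scatter). Compound 4 is reported only as a limit of the assay, so this step gives a minimum size and not an exact one. The earlier compounds did not show that a carbon-only aromatic ring at the end of this chain can leave a compound at the limit, and among the compounds that keep the rest of compound 2, only compound 2 itself gives a number, while compound 3 and compound 4 are both reported at the limit: the limit of > 25000 nM in this assay, at which 2 of the 4 values shown sit.

What the compounds shown leave open is whether the change from oxygen to sulfur in the chain or the change of ring accounts for this step, and compound 1 cannot settle it, as it differs from compound 4 in more than one place. A phenoxy or a benzylsulfanyl group at the same place, with the rest of compound 2 kept, would separate these two changes.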